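Swapping a Pyridine Amide for a Pyrimidine Amide

This account rests on a few compounds, and the source may have more. Where it says the series, first, only, none or still open, it means among the compounds named here.

Three compounds have been measured in a functional assay on HT-29 cells (Homo sapiens) for cytotoxicity, read by MTT assay, with a stated time of 72 h; on this read-out higher numbers stand for weaker inhibition and lower numbers for stronger inhibition:
Compound 1 `COc1cc2c(Oc3ccc(NC(=O)c4cc(-c5ccc(F)cc5)ccn4)cc3F)ccnc2cc1OCCCN1CCCCC1` gives 1370 nM.
Compound 2 `COc1cc2c(Oc3ccc(NC(=O)c4cc(-c5ccccc5F)ccn4)cc3F)ccnc2cc1OCCCN1CCCCC1` gives 320 nM.
Compound 3 `COc1cc2c(Oc3ccc(NC(=O)c4cc(-c5ccccc5)ccn4)cc3F)ccnc2cc1OCCCN1CCCCC1` gives 270 nM.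

Compound 3 gives the lowest number of the three, but compound 2 sits within the usual scatter of it, so those two cannot be ranked against each other; only compound 1 is clearly apart, as the step of a 5.1-fold lower number from compound 1 to compound 3 (0.71 log units; beyond the scatter) shows. Compound 4 `COc1cc2c(Oc3ccc(NC(=O)c4nccc(-c5ccccc5)n4)cc3F)ccnc2cc1OCCCN1CCCCC1` differs from compound 3 in one place: 4-phenylpyrimidin-2-yl in place of 4-phenylpyridin-2-yl on a carbonyl carbon. Neither measured step touches this change: a 4.3-fold lower number from compound 1 to compound 2 (0.63 log units; beyond the scatter) and a 1.2-fold lower number from compound 2 to compound 3 (0.07 log units; within the scatter) both concern a fluoro on the phenyl ring, and that phenyl ring stays as it is in compound 4. There is thus no measured guide for exchanging a pyridin-2-yl for a pyrimidin-2-yl, and the expectation for this assay is a step of no more than the scatter, in either direction, with a widened range for the lack of precedent. The step expected is a 1.3-fold higher number from compound 3 to compound 4 (0.11 log units; within the scatter). Compound 4 is estimated at 350 nM, with a range from 110 nM to 1100 nM.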

Compound 4, half-maximal inhibitory concentration: 260 nM
Estimate against measurement, compound 4: 1.3-fold (0.13 log units) above, and the stated range covers the measured number.
By their numbers in this assay, from the lowest: compounds 4, 3 and 2 (each within the scatter of the next); then compound 1.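

In this assay, 4-phenylpyrimidin-2-yl in place of 4-phenylpyridin-2-yl on the carbonyl carbon gives a 1.0-fold lower number from compound 3 to compound 4 (0.02 log units; within the scatter), so the two numbers cannot be told apart. The earlier steps shown here concerned only a fluoro on the phenyl ring, whereas this one shows that the ring carrying that phenyl can hold 2 hetero atoms rather than 1 with no visible shift in this cell read-out. Nothing available here bears on why the two compounds match.

Still open, going by these compounds, is whether the 4-fluorophenyl group, which separates compound 1 from compound 3, would have a similar effect on the pyrimidine ring of compound 4. Equally open, on these data alone, is how an amine or a carboxylic acid on that ring would read in this assay.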